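The source may hold more compounds than are shown below. What is called first, only, known or untested is meant among the compounds shown, and "the series" means these compounds.

Measured compounds:
Compound 1, `OCC#CCSc1cnc2ccccc2c1SCC#CCBr` — 0.6 ug/mL
Compound 2, `OCC#CCSc1cnc2ccccc2c1SCC#CCO` — 2.6 ug/mL

Among the measured compounds shown here, in a functional assay on CCRF-CEM cells (Homo sapiens) for cytotoxicity, read by sulforhodamine B assay, with a stated time of 72 h (a lower number here means a stronger inhibitor, a higher number a weaker inhibitor), compound 2 gives the highest of the two numbers seen so far; its nearest neighbour is compound 1, and the single step between them, a 4.3-fold higher number from compound 1 to compound 2 (0.64 log units; beyond the scatter), is the only one measured.

Compound 3, `C[Se]c1c(SCC#CCO)cnc2ccccc12`, differs from compound 2 as follows: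
a group of 2 heavy atoms (1 carbon, 1 selenium; no ring) in place of a group of 6 heavy atoms (4 carbon, 1 oxygen, 1 sulfur; no ring), on an aromatic carbon
The change sits on an aromatic carbon of the six-membered ring with one nitrogen, ortho to a fused ring and ortho to the group of 6 heavy atoms that stays.

For the measured compounds named here, no measured step bears on this change: the only step known, a 4.3-fold higher number from compound 1 to compound 2 (0.64 log units; beyond the scatter), exchanges a bromo for a hydroxy on a saturated chain carbon bound to a triple-bonded carbon and leaves the aromatic positions untouched. The replacement in compound 3 removes one hydrogen-bond donor and two acceptors together with the whole chain, which nothing in the series has probed. The expectation for compound 3 is therefore a step of roughly a 1.3-fold higher number from compound 2 to compound 3 (0.13 log units; within the scatter) from compound 2, held close to no change, with wide uncertainty in either direction. In this assay compound 3 is estimated at 3.5 ug/mL, within a range of 1 ug/mL to 12 ug/mL.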

Compound 3, concentration for 50% inhibition: 2.1 ug/mL
Compound 3: middle estimate off by 1.7-fold (0.22 log units), on the high side, within the range that was stated.
By their numbers in this assay, from the lowest: compound 1; then compounds 3 and 2 (each within the scatter of the next).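

At the aromatic carbon opposite the ring nitrogen, in this assay, the group of 2 heavy atoms (1 carbon, 1 selenium) replaces the whole group of 6 heavy atoms with its triple bond and hydroxy, giving a 1.2-fold lower number from compound 2 to compound 3 (0.09 log units; within the scatter), so that chain is not required at this position to stay at the level of compound 2. Against the bromo-bearing chain at the same carbon, the same replacement gives a 3.5-fold higher number from compound 1 to compound 3 (0.54 log units; beyond the scatter), which ties the lower number of compound 1 to that bromo-bearing chain rather than to any chain at this carbon, since compound 2 and compound 3 stay within the scatter of each other despite their very different groups there. No data at hand explain these numbers.

The compounds shown leave open whether selenium itself matters, since a methylthio group or an amine at this carbon would test how far the level of compound 3 depends on that atom. Also open, from the compounds shown here alone, is whether a bromo in place of the hydroxy on the remaining chain of compound 3, or a longer chain at the aromatic carbon, would reach the level of compound 1.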